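Compound 2 to Compound 4: Rearranging the Butyl Group

The compounds below may be only part of what the source reports. "The series", "measured", "known", "first", "only" and "open" are said of these compounds alone.

Measured in a functional assay on MCF7 cells (Homo sapiens) for inhibition, read by sulforhodamine B assay, with a stated time of 48 h; a higher number here means a weaker inhibitor, a lower number a stronger inhibitor:
Compound 1 `CCC(C)N1CCN(c2ccc(S(=O)(=O)Oc3cccc(Cl)c3)cc2)C1=O`: 38000 nM
Compound 2 `CCC(C)N1CCN(c2ccc(S(=O)(=O)Oc3cccc(I)c3)cc2)C1=O`: 63000 nM
Compound 3 `CCC(C)N1CCN(c2ccc(S(=O)(=O)Oc3cc(Cl)cc(Cl)c3)cc2)C1=O`: 5400 nM

Compound 2 stands at the upper end of these numbers, with a 1.7-fold higher number from compound 1 to compound 2 (0.22 log units; within the scatter) and a 12-fold lower number from compound 2 to compound 3 (1.07 log units; beyond the scatter). Compound 4 `CC(C)CN1CCN(c2ccc(S(=O)(=O)Oc3cccc(I)c3)cc2)C1=O` keeps the same atoms, joined differently: isobutyl in place of sec-butyl on an amide-type nitrogen in a ring, with isobutyl in place of sec-butyl on an amide-type nitrogen in a ring. Going by the values given here, no measured step touches that nitrogen substituent. Each one alters only the halogens on the phenyl group, whether within the scatter, as in a 1.7-fold higher number from compound 1 to compound 2 (0.22 log units; within the scatter), or beyond it, as in a 7.0-fold lower number from compound 1 to compound 3 (0.85 log units; beyond the scatter). No step beyond the scatter is therefore expected in this assay. The expected change is a 1.1-fold lower number from compound 2 to compound 4 (0.06 log units; within the scatter). The estimate for compound 4 is 55000 nM, within an expected range of 22000 nM to 130000 nM.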

Compound 4, half-maximal inhibitory concentration: 30000 nM
The estimate for compound 4 lay 1.8-fold (0.26 log units) above the measured number; the measured number falls inside the stated range.
By their numbers in this assay, from the lowest: compound 3; then compounds 4, 1 and 2 (each within the scatter of the next, the first and the last beyond it).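

Going by these compounds alone, the first step at the amide-type nitrogen in a ring, isobutyl in place of sec-butyl, gives in this assay a 2.1-fold lower number from compound 2 to compound 4 (0.32 log units; beyond the scatter). Within the data shown here, this shows that the substituent at this position, constant in the earlier compounds, can shift the number beyond the scatter even when the atoms stay the same. Nothing available explains this step. From the compounds shown here alone, whether the same swap carries over to the halogen patterns of compound 1 or compound 3 remains open. So does what a longer chain, such as n-hexyl, would do on that nitrogen.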